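Replacing the Amide on the Ring Nitrogen with a Pyridinylmethyl Group

This account rests on a few compounds, and the source may have more. Where it says the series, first, only, none or still open, it means among the compounds named here.

The measured compounds:
compound 1 `CC(C)C(=O)N1C[C@@H](C/C=C\CCC(=O)O)[C@@H](c2ccccc2O)C1`: 200 nM
compound 2 `O=C(O)CC/C=C\C[C@@H]1CN(S(=O)(=O)c2ccc(Cl)cc2)C[C@H]1c1ccccc1O`: 12.6 nM
compound 3 `O=C(O)CC/C=C\C[C@@H]1CN(S(=O)(=O)c2cccc3cnccc23)C[C@@H]1c1ccccc1O`: 0.316 nM

Three compounds sharing a core have been examined in a functional assay (Cavia porcellus) for antagonist activity at thromboxane A2 receptor (Homo sapiens); on this read-out higher numbers stand for weaker binding and lower numbers for tighter binding. Compound 1 gives 200 nM, the highest number of the three. The nearest to it is compound 2, whose value of 12.6 nM lies beyond the scatter, and the furthest is compound 3, which in this assay gives 0.316 nM, also well beyond the scatter. Both of the lower numbers belong to compounds carrying an aromatic ring on the ring nitrogen, whereas compound 1 carries an isopropylcarbonyl there.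

Compound 4 `O=C(O)CC/C=C\C[C@@H]1CN(Cc2cccnc2)C[C@@H]1c1ccccc1O` has not yet been measured. It differs from compound 1 in one place: (pyridin-3-yl)methyl in place of isopropylcarbonyl on an amine nitrogen in a ring. Among the compounds with values here, no single-change step between measured compounds is available, so the size of this step is estimated rather than derived. Given that compound 2 and compound 3 both give lower numbers than compound 1, a step toward a lower number is expected, though a smaller one than those. Compound 4 retains neither of their groups. The expected step is a 3.3-fold lower number from compound 1 to compound 4 (0.52 log units; beyond the scatter). Compound 4 is therefore estimated at 60 nM, within a range of 10 nM to 400 nM.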

Compound 4, dissociation constant: 1580 nM
Estimate against measurement, compound 4: 26-fold (1.42 log units) below, and the stated range ends below it.
By their numbers in this assay, from the lowest: compound 3; then compound 2; then compound 1; then compound 4.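

At the amine nitrogen in the ring, exchanging isopropylcarbonyl for (pyridin-3-yl)methyl moves this assay the wrong way: the result is a 7.9-fold higher number from compound 1 to compound 4 (0.90 log units; beyond the scatter), a step toward weaker binding. Within the data shown here, an aromatic ring on this nitrogen therefore does not bring a low number by itself, and compound 4 is the exception to the pattern suggested by the earlier compounds: it gives 1580 nM, whereas compound 3, which differs from it only on this nitrogen and has its aromatic ring system attached through a sulfonyl group, gives 0.316 nM in the same assay. Nothing at hand bears on why the number rises with this change.

This single step replaces the carbonyl and brings in the pyridine ring together, so the compounds shown cannot tell which part of the change accompanies the rise. A pyridin-3-ylcarbonyl group or a plain benzyl group on this nitrogen would separate the two, and a pyridin-3-ylsulfonyl group would show whether the pyridine ring gives a low number when attached through a sulfonyl group.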